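Benzyl in place of propyl on the shared core

This account rests on a few compounds, and the source may have more. Where it says the series, first, only, none or still open, it means among the compounds named here.

Within the data shown here, compound 2 `CCC[C@@H]1O[C@H](COCc2ccccc2)[C@@H](OCc2ccccc2)[C@H](OCc2ccccc2)[C@H]1O` is the one member of the series with a number: in a functional assay on HOS cells (Homo sapiens) for antiproliferative activity, read by sulforhodamine B assay (a lower number here means a stronger inhibitor of growth, a higher number a weaker inhibitor of growth), compound 2 gives 38600 nM. Compound 1 `CC[C@@H]1O[C@H](COCc2ccccc2)[C@@H](OCc2ccccc2)[C@H](OCc2ccccc2)[C@H]1OC(C)=O` reaches only a limit of this assay, > 50000 nM. Compound 3 `CCC[C@@H]1O[C@H](COCc2ccccc2)[C@@H](OCc2ccccc2)[C@H](OCc2ccccc2)[C@@H]1O` likewise sits at a limit, > 50000 nM. Among the measured compounds shown here, the single measured step, an at least 1.2-fold higher number from compound 2 to compound 3 (0.11 log units; that floor lies within the scatter), rests on the fact that compounds 2 and 3 differ only in the configuration as drawn together with the limit of > 50000 nM in this assay, at which 2 of the 3 values shown sit, and concerns configuration alone; it says nothing about a change of chain. Compound 4 `O[C@@H]1[C@@H](OCc2ccccc2)[C@H](OCc2ccccc2)[C@@H](COCc2ccccc2)O[C@H]1Cc1ccccc1` carries phenyl in place of ethyl on a saturated chain carbon bound to a saturated ring carbon. For the measured compounds named here, no measured step bears on this change, so no direction beyond the scatter can be drawn from the series. Compound 4 is expected to give 30000 nM, within 8000 nM to 100000 nM. The step of a 1.3-fold lower number from compound 2 to compound 4 (0.11 log units; within the scatter) is thus an estimate, not a measurement.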

Compound 4, concentration for 50% growth inhibition: 29200 nM
Beside the measured number, compound 4's estimate is 1.0-fold (0.01 log units) above it; measured number inside the range.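

In this assay, among these compounds, the first measured step for this change, propyl to benzyl, gives a 1.3-fold lower number from compound 2 to compound 4 (0.12 log units; within the scatter). A phenyl on a saturated chain carbon bound to a saturated ring carbon therefore leaves compound 4 with a number rather than a limit, and the added aromatic ring does not separate it from compound 2 beyond the scatter. Nothing shown accounts for this step.

Going by these compounds, whether an amine or a carboxylic acid at this place would move the number beyond the scatter remains open. Also open, on these data alone, is how the configuration that separates compound 2 from compound 3 behaves with benzyl in place of propyl.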